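Halogen swap on the urea aryl group in compound 4

The source may report more compounds than this note shows. Statements on the series, on what has been measured and on what is new or still open speak of the compounds shown alone.

Three measured compounds carry the same core and a urea linkage, all read in a functional assay on HCT-116 cells (Homo sapiens) for cytotoxicity, read by MTT assay, with a stated time of 48 h, in the presence of a further agent that is not named here; on this read-out lower numbers stand for an effect already at smaller amounts and higher numbers for an effect only at larger amounts of compound. Compound 1 `Cn1ncc2c(-c3ccc(F)cc3)cc(NNC(=O)Nc3cc(Cl)cc(Cl)c3)nc21` gives 39100 nM in this assay. Compound 2 `Cn1nc(C(F)(F)F)c2c(-c3ccccc3)cc(NNC(=O)Nc3cc(Cl)nc(Cl)c3)nc21` gives 18100 nM in this assay. Compound 3 `Cc1nn(C)c2nc(NNC(=O)Nc3cc(Cl)nc(Cl)c3)cc(-c3ccc(F)cc3)c12` gives 25200 nM in this assay. Compound 1 stands at the highest of the three numbers; against compound 3 the gap is within the scatter, so no order between those two can be stated, while against compound 2 the gap lies beyond the scatter.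

Compound 4 `Cn1ncc2c(-c3ccc(F)cc3)cc(NNC(=O)Nc3cc(F)cc(F)c3)nc21` has not yet been measured. It differs from compound 1 in one place: 3,5-difluorophenyl in place of 3,5-dichlorophenyl on an amide-type nitrogen. Among the measured compounds shown here, no measured pair in the set shows this change, so its effect cannot be read from the data. The step of a 1.0-fold higher number from compound 1 to compound 4 (0.01 log units; within the scatter) is expected to stay within the scatter, with no direction favoured. For compound 4 the expected value in this assay is 40000 nM, within a range from 15000 nM to 110000 nM.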

Compound 4, half-maximal effective concentration: 46200 nM
For compound 4 the middle estimate is 1.2-fold (0.06 log units) below the measured one; the measured number falls inside the stated range.
By their numbers in this assay, from the lowest: compounds 2, 3, 1 and 4 (each within the scatter of the next, the first and the last beyond it).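

In this assay, among the compounds shown here, the exchange of 3,5-dichlorophenyl for 3,5-difluorophenyl on an amide-type nitrogen gives the first single-place step, and a 1.2-fold higher number from compound 1 to compound 4 (0.07 log units; within the scatter) sets no order between the two compounds. At this position on the shared core, the two halogen pairs cannot be told apart on this read-out, so the exchange has no readable effect here. No measurement at hand explains this result.

As far as these compounds go, whether an amine, a carboxylic acid or a methoxy group in place of the two halogens would move the number beyond the scatter remains open. Also open, from the compounds shown here alone, is whether the same exchange would read alike in the settings of compound 2 and compound 3, whose urea aryl group differs from that of compound 1.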